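The compounds below may be only part of what the source reports. "The series", "measured", "known", "first", "only" and "open" are said of these compounds alone.

Series notes, on the hydrazone members built on the shared core. Compound 1 `CCCSc1nc(N/N=C/c2ccc(Cl)cc2)c2nnn(Cc3ccccc3)c2n1` carries the chlorophenyl group; in a functional assay on ECa-109 cells (Homo sapiens) for antiproliferative activity, read by MTT assay, with a stated time of 72 h (on this read-out higher numbers stand for weaker inhibition and lower numbers for stronger inhibition), compound 1 sits at > 64000 nM, which is a limit of the assay and not a number (the limit of > 64000 nM in this assay, at which 1 of the 3 values shown sits). Compound 2 `CCCSc1nc(N/N=C(\C)c2ccc(O)cc2)c2nnn(Cc3ccccc3)c2n1` gives 32500 nM in this assay. Compound 3 `CCCSc1nc(N/N=C(\C)c2ccccc2O)c2nnn(Cc3ccccc3)c2n1` gives 11100 nM, the lowest of the two numbers, placed there by a 2.9-fold lower number from compound 2 to compound 3 (0.47 log units; beyond the scatter) and by an at least 5.7-fold lower number from compound 1 to compound 3 (0.76 log units; beyond the scatter). Compound 4 `CCCSc1nc(N/N=C/c2ccccc2)c2nnn(Cc3ccccc3)c2n1` differs from compound 3 by a group of 8 heavy atoms (7 carbon, 1 nitrogen; one six-membered aromatic ring of carbon only) in place of a group of 10 heavy atoms (8 carbon, 1 nitrogen, 1 oxygen; one six-membered aromatic ring of carbon only), on a nitrogen on an aromatic ring. Both steps into compound 3 moved lower as the hydroxyl entered, so with the hydroxyl gone a higher number is expected, about a 3.6-fold higher number from compound 3 to compound 4 (0.56 log units; beyond the scatter). Compound 4 is thus estimated at 40000 nM, range 15000 nM to 100000 nM, with a fair chance of only a limit.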

Compound 4, half-maximal inhibitory concentration: > 64000 nM
Compound 4: no number, only a limit (the forecaster's own chance of this, stated with the estimate: 35%); middle value at least 1.6-fold (0.20 log units) away from the limit.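

In this assay compound 4 gives a limit and not a number, as compound 1 does: the limit of > 64000 nM in this assay, at which 2 of the 4 values shown sit.

Without the hydroxyl, the group on the nitrogen on an aromatic ring gives an at least 5.7-fold higher number from compound 3 to compound 4 (0.76 log units; beyond the scatter), a clear loss against the 2-hydroxyphenyl member, while the other step gives an at least 1.9-fold higher number from compound 2 to compound 4 (0.29 log units; that floor lies within the scatter), whose floor does not separate compound 4 from the 4-hydroxyphenyl member. The step from compound 1 to compound 4, hydrogen in place of chloro, cannot be read.

The entering group lacks both the oxygen and one carbon, and the compounds shown do not tell these two apart. Going by these compounds, whether an amine or a methoxy group in the place of that hydroxyl would hold the lower number also stays open.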